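Amine variation on the benzylic position of the shared core

This account rests on a few compounds, and the source may have more. Where it says the series, first, only, none or still open, it means among the compounds named here.

Notes on three measured compounds and one still to be run. In a functional assay on U-87MG ATCC cells (Homo sapiens) for cytotoxicity, read by MTT assay, with a stated time of 72 h (a lower number here means a stronger inhibitor, a higher number a weaker inhibitor), compound 1 `CCN(Cc1ccc(-c2ccnc3ccc(-c4cnc(OC)c(NS(=O)(=O)c5ccc(F)cc5F)c4)cc23)cc1)C1CCCCC1` gives 1450 nM, compound 2 `CNCCN(C)Cc1ccc(-c2ccnc3ccc(-c4cnc(OC)c(NS(=O)(=O)c5ccc(F)cc5F)c4)cc23)cc1` gives 254 nM, and compound 3 `COc1ncc(-c2ccc3nccc(-c4ccc(CN5CCCCC5)cc4)c3c2)cc1NS(=O)(=O)c1ccc(F)cc1F` gives 32 nM. Compound 3 stands at the lowest number of the three; the step of a 7.9-fold lower number from compound 2 to compound 3 (0.90 log units; beyond the scatter) is modest and the step of a 45-fold lower number from compound 1 to compound 3 (1.66 log units; beyond the scatter) is large, so compound 3 is the strongest inhibitor among the measured set, with compound 2 nearest and compound 1 furthest.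

Compound 4 `COc1ncc(-c2ccc3nccc(-c4ccc(CN5CCN(C(C)C)CC5)cc4)c3c2)cc1NS(=O)(=O)c1ccc(F)cc1F` differs from compound 3 in one place: 4-isopropylpiperazin-1-yl in place of piperidin-1-yl on a saturated chain carbon bound to an aromatic carbon. Every measured step in the series alters this same amine on the saturated chain carbon bound to an aromatic carbon, which makes a 45-fold lower number from compound 1 to compound 3 (1.66 log units; beyond the scatter), a 7.9-fold lower number from compound 2 to compound 3 (0.90 log units; beyond the scatter) and a 5.7-fold lower number from compound 1 to compound 2 (0.76 log units; beyond the scatter) the relevant comparisons. All of them end at piperidin-1-yl as the best of the three amines tried. Compound 2, which carries a second nitrogen on an open chain, sits a modest step above compound 3, and the larger cyclohexyl(ethyl)amino of compound 1 sits furthest. Adding a second ring hetero atom with an isopropyl group is therefore expected to cost a modest amount, a 2.3-fold higher number from compound 3 to compound 4 (0.37 log units; beyond the scatter), though within the wide uncertainty it could remain close to compound 3. The expected value for compound 4 in this assay is 75 nM, ranging from 25 nM to 220 nM.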

Compound 4, half-maximal inhibitory concentration: 468 nM
Beside the measured number, compound 4's estimate is 6.2-fold (0.80 log units) below it; measured number above the stated range.
By their numbers in this assay, from the lowest: compound 3; then compounds 2 and 4 (each within the scatter of the next); then compound 1.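

In this assay, a six-membered non-aromatic ring on the saturated chain carbon bound to an aromatic carbon is not enough to hold the low number of compound 3: a 15-fold higher number from compound 3 to compound 4 (1.17 log units; beyond the scatter), a large step for 4-isopropylpiperazin-1-yl in place of piperidin-1-yl. Compound 3 now stands apart from both ring and open-chain amines, since a 1.8-fold higher number from compound 2 to compound 4 (0.27 log units; within the scatter) leaves 4-isopropylpiperazin-1-yl level with methyl(2-(methylamino)ethyl)amino, and only a 3.1-fold lower number from compound 1 to compound 4 (0.49 log units; beyond the scatter) keeps it clear of cyclohexyl(ethyl)amino. No measurement available for these compounds accounts for the size of the step from piperidin-1-yl.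

This single change brings in the second ring nitrogen and the isopropyl group together, so their separate contributions cannot be read from these compounds; piperazin-1-yl and 4-methylpiperazin-1-yl would divide the step, and morpholin-4-yl would test a different second ring hetero atom. On these data alone, it also remains open whether piperidin-1-yl is a narrow optimum, which a pyrrolidin-1-yl or 4-methylpiperidin-1-yl group on the same carbon would help to settle.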